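Changing the Ring on the Nitrogen of Compound 2

A few compounds are considered here, and "the series" means these few. Any claim that something is new, unique, unknown or untested is made for them only; others in the source may bear on it.

In a functional assay on Raji cells (Homo sapiens) for cytotoxicity, with a stated time of 72 h (a lower number here means that less compound is needed, a higher number that more compound is needed for the effect), compound 2 (`C=C[C@@](C)(/C=C/c1ccc(Nc2ccc(OC)cc2)cc1)CCC=C(C)C`) gives > 26000 nM as a limit, not a number. Compound 1 (`C=C[C@@](C)(/C=C/c1ccc(O)c(/C=C/c2ccc(Cl)c(Cl)c2)c1)CCC=C(C)C`) gives > 26000 nM as a limit too. Compound 3 (`C=C[C@@](C)(/C=C/c1ccc(Nc2ccc(OC(F)(F)F)cc2)cc1)CCC=C(C)C`) likewise gives > 26000 nM as a limit. Compound 4 (`C=C[C@@](C)(/C=C/c1ccc(Nc2c(F)cc(F)cc2F)cc1)CCC=C(C)C`) brings one change to compound 2 (2,4,6-trifluorophenyl in place of 4-methoxyphenyl on a nitrogen on an aromatic ring). Among the measured compounds shown here, the only measured step that bears on this is a step that the two limits leave unreadable from compound 2 to compound 3 and it offers no size to carry over. Another limit is the likeliest result because the limit of > 26000 nM in this assay, at which 3 of the 3 values shown sit, and no direction can be read from it. The expected step is a step that the limit leaves unreadable from compound 2 to compound 4 and none beyond the scatter is foreseen. For compound 4 the estimated value is 30000 nM (range 12000 nM to 60000 nM).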

Compound 4, half-maximal effective concentration: > 26000 nM
Compound 4 was reported as a limit; the forecaster's own chance of this, stated with the estimate: 75%; the middle value does not contradict the limit.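

In this assay, among the compounds shown here, compound 2 and compound 4 are both reported only as limits, not numbers, so no step between them can be read. With all four compounds shown at such a limit, which change to the shared core would give a readable value in this assay stays open.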